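A few compounds are considered here, and "the series" means these few. Any claim that something is new, unique, unknown or untested is made for them only; others in the source may bear on it.

Among the measured compounds shown here, compound 2, `Cc1cccc(/C=C/C(=O)Nc2ccc3ncnc(Nc4cccc(Cl)c4)c3c2)n1`, gives the lower of the two numbers so far in a functional assay on HepG2 cells (Homo sapiens) for antiproliferative activity, read by MTT assay, with a stated time of 48 h (on this read-out lower numbers stand for stronger inhibition and higher numbers for weaker inhibition), at 4820 nM; compound 1, `O=C(/C=C/c1ccc(Br)s1)Nc1ccc2ncnc(Nc3cccc(Cl)c3)c2c1`, gives 8850 nM, and the step from one to the other, a 1.8-fold lower number from compound 1 to compound 2 (0.26 log units; within the scatter), stays within the scatter. Compound 3, `O=C(/C=C/c1cccnc1Cl)Nc1ccc2ncnc(Nc3cccc(Cl)c3)c2c1`, differs from compound 2 only in that (2-chloropyridin-3-yl in place of 6-methylpyridin-2-yl on a double-bonded chain carbon bound to a double-bonded chain carbon). For the measured compounds named here, the one measured step that bears on this position is the small move from compound 1 to compound 2, so compound 3 is expected to show no step beyond the scatter, a 1.1-fold higher number from compound 2 to compound 3 (0.06 log units; within the scatter). Compound 3 is therefore estimated at 5500 nM, with a range from 1800 nM to 17000 nM in this assay.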

Compound 3, half-maximal inhibitory concentration: 4420 nM
Beside the measured number, compound 3's estimate is 1.2-fold (0.09 log units) above it; the range from low to high includes it.
By their numbers in this assay, from the lowest: compounds 3, 2 and 1 (each within the scatter of the next).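

In this assay, exchanging one pyridine group for another gives a 1.1-fold lower number from compound 2 to compound 3 (0.04 log units; within the scatter), and the thiophene group against 2-chloropyridin-3-yl gives a 2.0-fold lower number from compound 1 to compound 3 (0.30 log units; within the scatter). Among the compounds shown here, this position on the double-bonded chain carbon has now carried three different aromatic groups, with no pair separated beyond the scatter, and moving from a methyl-bearing to a chlorine-bearing pyridine does not separate them either. Nothing available explains this result.

The compounds shown leave open whether a non-aromatic group on this carbon, such as an amine or a carboxylic acid, would move the number beyond the scatter. They also leave open whether an unsubstituted phenyl would do so.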